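The compounds below may be only part of what the source reports. "The series", "measured", "known", "first", "only" and "open" are said of these compounds alone.

Measured so far in an assay on HEK293 cells for positive allosteric modulation of metabotropic glutamate receptor 5 (Homo sapiens), read by FLIPR; a lower number here means that less compound is needed, a higher number that more compound is needed for the effect:
- compound 1, `O=C(C1CCC2(CCC2)CC1)N1CC(c2nc(-c3cccc(Cl)c3)no2)C1`: 1100 nM
- compound 2, `COC1CCN(C(=O)N2CC(c3nc(-c4cccc(Cl)c4)no3)C2)CC1`: > 10000 nM, a limit of the assay
- compound 3, `O=C(c1ccccc1F)N1CC(c2nc(-c3cccc(Cl)c3)no2)C1`: > 10000 nM, a limit of the assay
- compound 4, `COC1CCCN(C(=O)N2CC(c3nc(-c4cccc(Cl)c4)no3)C2)C1`: not yet measured

Compound 3 stands only at a limit of this assay, not at a number; the same is true of compound 2, so that the limit of > 10000 nM in this assay, at which 2 of the 3 values shown sit, holds for most of the series. Compound 1 alone gives a number. Among the measured compounds shown here, from it, an at least 9.0-fold higher number from compound 1 to compound 2 (0.95 log units; beyond the scatter) and an at least 9.0-fold higher number from compound 1 to compound 3 (0.95 log units; beyond the scatter) both end at that limit, so the two amide groups on the carbonyl carbon other than the one in compound 1 are indistinguishable in this assay, and a step that the two limits leave unreadable from compound 2 to compound 3 cannot be read.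

The change to compound 4 is 3-methoxypiperidin-1-yl in place of 2-fluorophenyl on a carbonyl carbon. For the measured compounds named here, compound 4 is close to compound 2, differing only in where the methoxy sits on the piperidine ring; compound 2 sits at the limit, and no measured step shows the position of a methoxy group on this ring making a readable difference. Compound 4 is therefore expected to give 12000 nM in this assay, in the range 4000 nM to 40000 nM, most probably reported again as a limit rather than a number. The step that the limit leaves unreadable from compound 3 to compound 4 is thus expected to show no change beyond the scatter.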

Compound 4, half-maximal effective concentration: > 10000 nM
Compound 4: only a limit was reported; the forecaster's own chance of this, stated with the estimate: 70%; the middle value lies beyond the limit too.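

Moving the methoxy group around the piperidine ring, from 4-methoxypiperidin-1-yl to 3-methoxypiperidin-1-yl, does not bring a number into reach in this assay; compound 4 gives > 10000 nM, which is a limit of the assay and not a number. Among the compounds shown here, the only readable step is an at least 9.0-fold higher number from compound 1 to compound 4 (0.95 log units; beyond the scatter), while the steps among compound 2, compound 3 and compound 4 cannot be read. Among the groups shown on the carbonyl carbon, only the one in compound 1 gives a number, and no compound goes against this, as 2-fluorophenyl and both methoxypiperidines end at the same limit: the limit of > 10000 nM in this assay, at which 3 of the 4 values shown sit.

On these data alone, the true values behind the limits for compound 2, compound 3 and compound 4 remain unknown, so these three groups cannot be ranked against one another. As far as these compounds go, it also remains open whether a plain cyclohexyl or a 4,4-dimethylcyclohexyl group on the carbonyl carbon would still give a number as compound 1 does, and whether an unsubstituted piperidine or a 4-methylpiperidine would differ from the methoxypiperidines.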